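Series notes: step from compound 3 to compound 4

The source may hold more compounds than are shown below. What is called first, only, known or untested is meant among the compounds shown, and "the series" means these compounds.

Measured in a functional assay on PC-12 cells (Rattus norvegicus) for cytotoxicity, read by MTT assay, with stated times of 3 h and 2 h, tested at 0.1 uM; a lower number here means a weaker effect, a higher number a stronger effect of the compound at the concentration tested:
compound 1 `COc1ccc(-c2cc3ccc(OCCCn4cc(CNC(=O)CCCCC5CCSS5)nn4)cc3oc2=O)cc1`: 42%
compound 2 `O=C(CCCCC1CCSS1)NCc1cn(CCCCOc2ccc3ccc(=O)oc3c2)nn1`: 40.5%
compound 3 `COc1ccc(-c2cc3ccc(OCCCCn4cc(CNC(=O)CCCCC5CCSS5)nn4)cc3oc2=O)cc1`: 32.1%

Compound 3 has the smallest of the three numbers, yet the step of a number 8.4 percentage points lower from compound 2 to compound 3 (within the scatter) lies within the scatter, and its gap to compound 1 is within the scatter as well, so the three cannot be ranked.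

Compound 4 `O=C(CCCCC1CCSS1)NCc1cn(CCCCOc2ccc3cc(-c4ccc(Cl)c(Cl)c4)c(=O)oc3c2)nn1` is unmeasured. The change is 3,4-dichlorophenyl in place of 4-methoxyphenyl on an aromatic carbon. Among the measured compounds shown here, the only measured step, a number 8.4 percentage points lower from compound 2 to compound 3 (within the scatter), concerns the presence of the 4-methoxyphenyl, not its exchange for 3,4-dichlorophenyl, so no step here bears directly on this change. Compound 4 is therefore expected to show a step of a number 2.9 percentage points higher from compound 3 to compound 4 (within the scatter), within the scatter. For compound 4 the estimate in this assay is 35%, ranging from 22% to 50%.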

Compound 4, a percentage reported as activity, at one concentration (the size of the read-out at that concentration, not a potency): 39.6%
Estimate against measurement, compound 4: 4.6 percentage points below; measured number inside the range.
By their numbers in this assay, from the lowest: compounds 3, 4, 2 and 1 (each within the scatter of the next).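

In this assay, 3,4-dichlorophenyl in place of 4-methoxyphenyl on this aromatic carbon gives a number 7.5 percentage points higher from compound 3 to compound 4 (within the scatter) and so does not separate the two aryl groups. Set against hydrogen at the same carbon, 3,4-dichlorophenyl gives a number 0.9 percentage points lower from compound 2 to compound 4 (within the scatter) and so does not separate from the unsubstituted position either. No measurement at hand offers an explanation for these numbers.

Open, on these data alone, is whether a non-aryl group on this carbon, such as a carboxylic acid or an aminomethyl group, would move the number beyond the scatter. Also open, as far as these compounds go, is whether 3,4-dichlorophenyl would read the same on a shorter linking chain.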